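The source may hold more compounds than are shown below. What is called first, only, known or untested is meant among the compounds shown, and "the series" means these compounds.

Compounds measured so far in a functional assay on MCF7 cells (Homo sapiens) for antiproliferative activity, read by MTT assay, with a stated time of 24 h; on this read-out higher numbers stand for weaker inhibition and lower numbers for stronger inhibition:
Compound 1 `CCn1c(C(=O)N[C@@H](C)C(=O)OC)ccc1C(CC)(CC)c1ccc(OCS(=O)(=O)c2ccccc2)c(C)c1`: 43700 nM
Compound 2 `CCN(CC)CCNC(=O)c1ccc(C(CC)(CC)c2ccc(OCS(=O)(=O)c3ccccc3)c(C)c2)n1CC`: 4680 nM
Compound 3 `CCn1c(C(=O)N[C@@H](C)CO)ccc1C(CC)(CC)c1ccc(OCS(=O)(=O)c2ccccc2)c(C)c1`: 10800 nM

Compound 3 stands second highest of the three numbers in this assay. Its nearest neighbour is compound 2, with a 2.3-fold higher number from compound 2 to compound 3 (0.36 log units; beyond the scatter); the furthest is compound 1, with a 4.0-fold lower number from compound 1 to compound 3 (0.61 log units; beyond the scatter). All three share the same core, and they differ only in the group on the amide-type nitrogen.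

Compound 4 `CCn1c(C(=O)N[C@@H](CO)CCCO)ccc1C(CC)(CC)c1ccc(OCS(=O)(=O)c2ccccc2)c(C)c1` is the next member of this set. The change from compound 3 is a group of 7 heavy atoms (5 carbon, 2 oxygen; no ring) in place of a group of 4 heavy atoms (3 carbon, 1 oxygen; no ring), on an amide-type nitrogen. The group that enters carries a second hydroxyl and is longer than the 1-(hydroxymethyl)ethyl that leaves.

Both measured steps concern this same amide-type nitrogen. The step of a 4.0-fold lower number from compound 1 to compound 3 (0.61 log units; beyond the scatter) shows that bringing in a hydroxymethyl in place of methoxycarbonyl gave a modest gain, and the step of a 9.3-fold lower number from compound 1 to compound 2 (0.97 log units; beyond the scatter) shows a modest gain for 2-(diethylamino)ethyl. Among the measured compounds shown here, no measured step adds a second hydroxyl to a chain already bearing one, so the direction is open. Given that compound 3 gives 10800 nM and the group exchanged is a hydroxyl-bearing chain for another, the step is expected to stay near or within the scatter, a 1.2-fold lower number from compound 3 to compound 4 (0.08 log units; within the scatter). Compound 4 is therefore estimated at 9000 nM in this assay, with a range from 3500 nM to 25000 nM.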

Compound 4, half-maximal inhibitory concentration: 29600 nM
The estimate for compound 4 lay 3.3-fold (0.52 log units) below the measured number, and the stated range ends below it.
By their numbers in this assay, from the lowest: compound 2; then compound 3; then compounds 4 and 1 (each within the scatter of the next).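

In this assay, exchanging one hydroxyl-bearing chain for another on the amide-type nitrogen does change the read-out, and the longer group with its second hydroxyl gives a 2.7-fold higher number from compound 3 to compound 4 (0.44 log units; beyond the scatter). This removes the advantage that compound 3 held over the methyl ester compound 1: the new diol sits level with that ester, at a 1.5-fold lower number from compound 1 to compound 4 (0.17 log units; within the scatter), while the 2-(diethylamino)ethyl group of compound 2, with the same heavy-atom count as the entering group, keeps the lowest number of the set, as the step of a 6.3-fold higher number from compound 2 to compound 4 (0.80 log units; beyond the scatter) shows. No measurement shown here offers an explanation for this loss.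

The longer chain and the second hydroxyl enter together in compound 4, so the compounds shown leave open which of the two accounts for the step. A chain of the same length with no second hydroxyl, or one carrying an amine in place of that hydroxyl, would help to separate the two, and would also show whether the lower number of compound 2 goes with its diethylamino group rather than with chain length.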